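The source may hold more compounds than are shown below. What is called first, only, known or untested is meant among the compounds shown, and "the series" means these compounds.

Compound 3, whose structure is `CC(C)c1onc(-c2c(Cl)cccc2Cl)c1COc1ccc(-c2nc3ccc(C(=O)O)cc3n2CC2CCCCC2)c(F)c1`, is the strongest of the two compounds with a number here: in an assay on HEK-293T cells for antagonist activity at vitamin D3 receptor (Homo sapiens), read by a luciferase reporter, with a stated time of 24 h (on this read-out higher numbers stand for weaker inhibition and lower numbers for stronger inhibition), compound 3 gives 840 nM. Compound 1, with structure `CC(C)c1onc(-c2c(Cl)cccc2Cl)c1COc1ccc(-c2nc3ccc(C(=O)O)cc3n2C(C)C)cc1`, gives 3550 nM in this assay. Compound 2, with structure `CC(=O)N1CCC(n2c(-c3ccc(OCc4c(-c5c(Cl)cccc5Cl)noc4C(C)C)cc3)nc3ccc(C(=O)O)cc32)CC1`, reaches only a limit of this assay, > 10000 nM. For the measured compounds named here, the one measured step, an at least 2.8-fold higher number from compound 1 to compound 2 (0.44 log units; beyond the scatter), concerns a group on an aromatic nitrogen and not the ring carbon that changes here.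

Compound 4, with structure `CC(C)c1onc(-c2c(Cl)cccc2Cl)c1COc1ccc(-c2nc3ccc(C(=O)O)cc3n2CC2CCCCC2)cc1`, differs from compound 3 by hydrogen in place of fluoro on an aromatic carbon. Going by the values given here, no measured pair shows this change on its own. Compound 1 and compound 3 differ both at the aromatic nitrogen and by this fluoro, so their gap cannot be split between the two changes. The step from compound 3 to compound 4 is therefore expected to be no more than modest, and if anything towards a higher number, so that compound 4 is estimated at 1600 nM, between 500 nM and 5000 nM, a change of a 1.9-fold higher number from compound 3 to compound 4 (0.28 log units; within the scatter).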

Compound 4, half-maximal inhibitory concentration: 346 nM
Compound 4: the middle estimate sits 4.6-fold (0.67 log units) above what was measured; measured number outside the range, below it.
By their numbers in this assay, from the lowest: compound 4; then compound 3; then compound 1. At a limit, above all of these: compound 2.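

Removing the fluoro gives a 2.4-fold lower number from compound 3 to compound 4 (0.39 log units; beyond the scatter), so in this assay hydrogen gives the lower number of the two on this aromatic carbon, ortho to a large group and meta to a large group, at least with cyclohexylmethyl on the aromatic nitrogen. For the compounds shown here, compound 4 also gives the first clean reading of that nitrogen group, since cyclohexylmethyl in place of isopropyl gives a 10-fold lower number from compound 1 to compound 4 (1.01 log units; beyond the scatter). Compound 2 stands at a limit, so an at least 28-fold lower number from compound 2 to compound 4 (1.46 log units; beyond the scatter) marks only a minimum for swapping 1-acetylpiperidin-4-yl for cyclohexylmethyl: the limit of > 10000 nM in this assay, at which 1 of the 4 values shown sits.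

Going by these compounds alone, the fluoro change is seen with only one nitrogen group, so whether hydrogen also gives the lower number with isopropyl there remains open. The compounds shown also leave open how a chlorine, a methyl or a methoxy group would behave on this carbon.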